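Sulfur oxidation state stepped down once more in compound 3

This account rests on a few compounds, and the source may have more. Where it says the series, first, only, none or still open, it means among the compounds named here.

Compound 1: `CS(=O)(=O)C1=C(N)C(=O)c2cccnc2C1=O` — > 200000 nM
Compound 2: `C[S+]([O-])C1=C(N)C(=O)c2cccnc2C1=O` — > 200000 nM
Compound 3: `CSC1=C(N)C(=O)c2cccnc2C1=O` — not yet measured

In a functional assay on cells (Neutrophil, Homo sapiens) for inhibition, read by WST assay, with a stated time of 20 min (a lower number here means a stronger inhibitor, a higher number a weaker inhibitor), compound 1 gives only a limit, > 200000 nM. Compound 2 also gives only a limit in this assay, > 200000 nM. The step that the two limits leave unreadable from compound 1 to compound 2 cannot be read because of the limit of > 200000 nM in this assay, at which 2 of the 2 values shown sit. Compound 3 differs from compound 2 by a group of 2 heavy atoms (1 carbon, 1 sulfur; no ring) in place of a group of 3 heavy atoms (1 carbon, 1 oxygen, 1 sulfur; no ring), on a double-bonded ring carbon. Within the data shown here, no measured step bears on this change, and no value here is a number. Compound 3 is therefore expected to sit near 200000 nM, with a range of 40000 nM to 1000000 nM. The expected step of a number no higher from compound 2 to compound 3 (the limit leaves the size open) is estimated as nothing beyond the scatter, most likely another limit.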

Compound 3, half-maximal inhibitory concentration: > 150000 nM
Compound 3: a limit, no number; the forecaster's own chance of this, stated with the estimate: 70%; the middle value is on the limit's open side.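

Compound 3 gives only a limit, > 150000 nM, in this assay. Among these compounds, no step among compound 1, compound 2 and compound 3 can be read. The compounds shown leave open whether the group on the double-bonded ring carbon affects inhibition at all.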